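Cyclopropyl to cyclobutyl in a corticotropin-releasing factor antagonist series

A few compounds are considered here, and "the series" means these few. Any claim that something is new, unique, unknown or untested is made for them only; others in the source may bear on it.

Measured compounds:
- compound 1, `CCCN(CC1CCC1)C(=O)c1c(C)nc2n1CCCN2c1c(C)cc(C)cc1C`, 3300 nM
- compound 2, `CCCN(CC1CC1)C(=O)c1c(C)nc2n1CCCN2c1c(C)cc(C)cc1C`, > 5000 nM
- compound 3, `CCCN(Cc1c(C(F)(F)F)nc2n1CCCN2c1c(C)cc(C)cc1C)CC1CC1`, 32 nM

All values come from an in vitro assay on IMR-32 cells for displacement of a labelled ligand from corticotropin-releasing factor receptor 1 (Homo sapiens); a higher number here means a weaker inhibitor, a lower number a stronger inhibitor. For compound 2 the value is a limit of the assay, not a number (the limit of > 5000 nM in this assay, at which 1 of the 3 values shown sits). Compound 1 differs from compound 2 by cyclobutyl in place of cyclopropyl on a saturated chain carbon bound to an amide-type nitrogen; the step is an at least 1.5-fold lower number from compound 2 to compound 1 (0.18 log units; that floor lies within the scatter). Compound 3 carries a different core; the difference between the two cores of compound 3 and compound 2 is not broken down here. Compound 3 gives the lowest number of the two numbers shown, and compound 1 gives the higher of the two, a gap that lies beyond the usual scatter.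

Compound 4, `CCCN(Cc1c(C(F)(F)F)nc2n1CCCN2c1c(C)cc(C)cc1C)CC1CCC1`, is not yet measured. It differs from compound 3 by cyclobutyl in place of cyclopropyl on a saturated chain carbon bound to an amine nitrogen. The place differs from the earlier pair: there the saturated chain carbon is bound to an amide-type nitrogen, here to an amine nitrogen, so this is the same kind of change, not the same change. Among the compounds with values here, the only measured step of this kind, an at least 1.5-fold lower number from compound 2 to compound 1 (0.18 log units; that floor lies within the scatter), is small and rests on a limit. Compound 4 is therefore expected to stay near compound 3, an expected step of a 1.3-fold lower number from compound 3 to compound 4 (0.11 log units; within the scatter) in this assay. The estimate for compound 4 is 25 nM, between 8 nM and 80 nM.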

Compound 4, inhibition constant: 21 nM
Compound 4: middle estimate off by 1.2-fold (0.08 log units), on the high side; the range from low to high includes it.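

In this assay, cyclobutyl in place of cyclopropyl on a saturated chain carbon bound to an amine nitrogen gives a 1.5-fold lower number from compound 3 to compound 4 (0.18 log units; within the scatter), so on this core the change does not move the number beyond the scatter. Set beside the pair with the amide-type nitrogen, the change reads as follows: the same change on two cores in this assay, an at least 1.5-fold lower number (0.18 log units; that floor lies within the scatter) from compound 2 to compound 1 and a 1.5-fold lower number (0.18 log units; within the scatter) from compound 3 to compound 4; the limit leaves it open whether they differ Compound 2 is at a limit of the assay, > 5000 nM, so the step on its core has only a floor, and these two pairs show neither that the change carries over from one core to the other with the same size nor that it does not.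

Open, as far as these compounds go, is whether cyclopentyl, or a longer chain such as butyl, in place of the cyclobutyl keeps the number seen for compound 4 on its core. Also open, from the compounds shown here alone, is whether a hydroxyl group or an amine on the propyl chain would leave either core unchanged in this assay.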